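Cytotoxicity tolerance across three close analogues

The source may hold more compounds than are shown below. What is called first, only, known or untested is meant among the compounds shown, and "the series" means these compounds.

Compound 1 `COC(=O)C[C@H](NC(=O)OC(C)(C)C)C(=O)N(Cc1ccc(C)cc1)C1(C(=O)NCc2ccccc2)CCN(Cc2ccccc2)CC1` and compound 2 `COC(=O)C[C@H](NC(=O)OC(C)(C)C)C(=O)N(Cc1ccc(Cl)cc1)C1(C(=O)NCc2ccccc2)CCN(Cc2ccccc2)CC1` share one core and differ in a single place, chloro in place of methyl on an aromatic carbon. In an ADME assay on MDCK cells (Canis lupus familiaris) for cytotoxicity, read by microscopy, with a stated time of 72 h (a higher number here means that more compound is tolerated, a lower number that less compound is tolerated), compound 1 gives > 100000 nM, which is a limit of the assay and not a number. In this assay, for the measured compounds named here, compound 2 gives 100000 nM, the only number in the set. The step of a number no higher from compound 1 to compound 2 (the limit leaves the size open) cannot be sized because the limit of > 100000 nM in this assay, at which 1 of the 2 values shown sits, caps one side of it.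

Compound 3 `COC(=O)C[C@H](NC(=O)OC(C)(C)C)C(=O)N(Cc1ccccc1F)C1(C(=O)NCc2ccccc2)CCN(Cc2ccccc2)CC1` is not yet measured. It differs from compound 2 in one place: 2-fluorophenyl in place of 4-chlorophenyl on a saturated chain carbon bound to an amide-type nitrogen. Going by the values given here, only the step from compound 1 to compound 2 bears on this change, and its size is not readable. With no readable step, compound 3 is expected to sit near compound 2, a step of no change at the digits printed from compound 2 to compound 3 (within the scatter) within the scatter. The estimate for compound 3 in this assay is 100000 nM, ranging from 30000 nM to 200000 nM.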

Compound 3, minimum cytotoxic concentration: 20000 nM
Beside the measured number, compound 3's estimate is 5.0-fold (0.70 log units) above it; the whole stated range lies above it.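

In this assay, 2-fluorophenyl in place of 4-chlorophenyl gives a 5.0-fold lower number from compound 2 to compound 3 (0.70 log units; beyond the scatter), so this position on a saturated chain carbon bound to an amide-type nitrogen now shows a change that can be read, which the earlier step from 4-methylphenyl to 4-chlorophenyl did not. In place of 4-methylphenyl, the same group gives an at least 5.0-fold lower number from compound 1 to compound 3 (0.69 log units; beyond the scatter), and with both steps beyond the scatter, compound 3 is the least tolerated of the three. Only one side of this second step is fixed: the limit of > 100000 nM in this assay, at which 1 of the 3 values shown sits.

The change from 4-chlorophenyl to 2-fluorophenyl alters both the halogen and where it sits on the ring, and these compounds do not separate the two. Going by these compounds, what 4-fluorophenyl or 2-chlorophenyl would give at this position remains open.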